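The compounds below may be only part of what the source reports. "The series", "measured", "known", "first", "only" and "open" are said of these compounds alone.

Going by the values given here, compound 2 `Nc1nc(-c2cnccn2)nc2sc(Cc3ccccc3)cc12` gives 91 nM in a functional assay on CHO-K1 cells for antagonist activity at adenosine receptor A1 (Homo sapiens), read by a beta-galactosidase reporter and cAMP accumulation, with stated times of 15 min and 6 h (on this read-out higher numbers stand for weaker inhibition and lower numbers for stronger inhibition), and holds the lowest of the two numbers measured so far. Compound 1 `N#Cc1ccc(-c2nc(N)c3cc(Cc4ccccc4)sc3n2)o1` gives 3160 nM in this assay. Among the compounds with values here, the only measured step, a 35-fold lower number from compound 1 to compound 2 (1.54 log units; beyond the scatter), shows how strongly the group at this position can move the number. Compound 3 `N#Cc1cncc(-c2nc(N)c3cc(Cc4ccccc4)sc3n2)c1` differs from compound 2 by 5-cyanopyridin-3-yl in place of pyrazin-2-yl on an aromatic carbon. Within the data shown here, the change keeps a six-membered aromatic ring but brings back a nitrile, which no measured step matches directly. A moderate rise in the number is expected, a 2.2-fold higher number from compound 2 to compound 3 (0.34 log units; beyond the scatter). Compound 3 is therefore estimated at 200 nM, within a range of 50 nM to 1000 nM.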

Compound 3, inhibition constant: 1160 nM
For compound 3 the middle estimate is 5.8-fold (0.76 log units) below the measured one, and the stated range ends below it.
By their numbers in this assay, from the lowest: compound 2; then compound 3; then compound 1.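

In this assay the result is a 13-fold higher number from compound 2 to compound 3 (1.11 log units; beyond the scatter) and so a six-membered aromatic ring at this position does not by itself keep the number low. Set against the furan, the same nitrile-bearing pyridine gives only a 2.7-fold lower number from compound 1 to compound 3 (0.44 log units; beyond the scatter) and so both nitrile-bearing groups remain well above pyrazin-2-yl. No evidence is available to account for these differences.

The compounds shown leave open whether the nitrile or the change of ring carries the rise. They also leave open how a plain pyridin-3-yl, or a ring bearing an amine or a carboxylic acid, would read.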